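Replacing Methoxy with Hydroxymethyl: An Expected Small Step

The source may hold more compounds than are shown below. What is called first, only, known or untested is meant among the compounds shown, and "the series" means these compounds.

Values in a functional assay on MCF-10A cells (Homo sapiens) for antiproliferative activity, with a stated time of 48 h; on this read-out higher numbers stand for an effect only at larger amounts of compound and lower numbers for an effect already at smaller amounts:
- Compound 1 `COc1ccc2nc(C)cc(NCc3ccccc3F)c2c1`: 14000 nM
- Compound 2 `COc1ccc2nc(C)cc(NCc3ccccc3OC)c2c1`: 25200 nM

Compound 2 gives 25200 nM, and compound 1, at 14000 nM, stands level with it within the scatter. The next structure, compound 3 `COc1ccc2nc(C)cc(NCc3ccccc3CO)c2c1`, differs from compound 2 as follows: hydroxymethyl in place of methoxy on an aromatic carbon. This puts hydroxymethyl in place of methoxy on an aromatic carbon, ortho to a large group. Within the data shown here, one measured step bears on this change: a 1.8-fold higher number from compound 1 to compound 2 (0.26 log units; within the scatter), with methoxy in place of fluoro at the same place. Among the measured compounds shown here, no measured compound carries hydroxymethyl, so this evidence is thin. In this assay, no step beyond the scatter is expected in either direction, though the range must stay wide. Compound 3 is estimated at 20000 nM, with an expected range from 8000 nM to 50000 nM. The estimate means an expected 1.3-fold lower number from compound 2 to compound 3 (0.10 log units; within the scatter).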

Compound 3, half-maximal effective concentration: 22900 nM
Compound 3: the middle estimate sits 1.1-fold (0.06 log units) below what was measured, within the range that was stated.
By their numbers in this assay, from the lowest: compounds 1, 3 and 2 (each within the scatter of the next).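

In this assay, hydroxymethyl in place of methoxy on this aromatic carbon, ortho to a large group, gives a 1.1-fold lower number from compound 2 to compound 3 (0.04 log units; within the scatter), so the entry of a hydrogen-bond donor of the same heavy-atom count leaves the number within the scatter. Hydroxymethyl in place of fluoro gives a 1.6-fold higher number from compound 1 to compound 3 (0.21 log units; within the scatter), also within the scatter, so fluoro, methoxy and hydroxymethyl now stand level at this place, where the earlier pair offered only two groups. Nothing measured here gives a reason for this flat result.

Going by these compounds, it remains open whether an amine, a carboxylic acid or a longer chain at this carbon would move the number beyond the scatter in this assay. On these data alone, it also remains open whether these three groups would stay level on another carbon of the same ring.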